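A few compounds are considered here, and "the series" means these few. Any claim that something is new, unique, unknown or untested is made for them only; others in the source may bear on it.

Measured compounds in an ADME assay on MOLT-3 cells (Homo sapiens) for cytotoxicity, with a stated time of 7 days; on this read-out higher numbers stand for lower toxicity in this test and lower numbers for higher toxicity in this test:
compound 1 `CC(C)CNc1nc(N)nc2c1ncn2/C=C1/CC1(CO)CO`: "not determined" (no result reported)
compound 2 `CCCCCCSc1nc(N)nc2c1ncn2/C=C1/CC1(CO)CO`: > 20000 nM (a limit)
compound 3 `Nc1nc(SC2CCCC2)c2ncn(/C=C3/CC3(CO)CO)c2n1`: > 20000 nM (a limit)

Compound 3 gives > 20000 nM, which is a limit of the assay and not a number. Its place in the series can therefore be stated only through (the limit of > 20000 nM in this assay, at which 2 of the 3 values shown sit), which it shares with compound 2. Compound 1 offers no comparison, since no result was reported for it.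

The next compound is compound 4 `CCCCOc1nc(N)nc2c1ncn2/C=C1/CC1(CO)CO`, and the change from compound 3 is butoxy in place of cyclopentylsulfanyl on an aromatic carbon. The butoxy group sits on the same aromatic carbon, meta to the amino group.

Within the data shown here, only one measured step bears on this change: a step that the two limits leave unreadable from compound 2 to compound 3. It also concerns the group at this place, but it gives no size or direction. Among the measured compounds shown here, no compound with butoxy at this place has been measured, so the data offer no measured effect to carry over.

The working expectation is that compound 4 stays close to the limit shared by compound 2 and compound 3, with no step beyond the scatter and no direction that can be supported. The expected step is a step that the limit leaves unreadable from compound 3 to compound 4. In this assay, the estimate for compound 4 is 25000 nM, with an expected range from 10000 nM to 60000 nM.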

Compound 4, half-maximal cytotoxic concentration: > 20000 nM
Compound 4 ended at the assay's limit (the forecaster's own chance of this, stated with the estimate: 75%); the middle value is on the limit's open side.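

In this assay compound 4 gives > 20000 nM and this is a limit of the assay, not a number. Among these compounds, with compound 2 and compound 3 also at the limit, no step among the three can be read. The compounds shown leave open how hexylsulfanyl, cyclopentylsulfanyl and butoxy rank against one another in this assay.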